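The compounds below may be only part of what the source reports. "The series", "measured", "known", "first", "only" and "open" are said of these compounds alone.

Values so far in an in vitro ADME assay on microsomes from liver (Homo sapiens) for metabolic stability, read by LC-MS, tested at 1 uM (on this read-out higher numbers stand for a longer-lived compound and lower numbers for a shorter-lived compound), are these.
compound 1 `CC(C)C(=O)N/C(=N/c1nccn1C(C)C)Nc1ccc(Cl)c(Cl)c1` gives > 1 h
compound 2 `CCC(CC)C(=O)N/C(=N/c1nccn1C(C)C)Nc1ccc(Cl)c(Cl)c1` gives > 1 h
compound 3 `CC(C)n1ccnc1/N=C(/NC(=O)OC(C)(C)C)Nc1ccc(Cl)c(Cl)c1` gives > 1 h

Compound 2 stands at > 1 h as a limit and not a number. The other two values are the same kind of limit (the limit of > 1 h in this assay, at which 3 of the 3 values shown sit).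

Compound 4 `CCC(CC)C(=O)N/C(=N/c1nccn1C(C)(C)C)Nc1ccc(Cl)c(Cl)c1` differs from compound 2 at one place, isopropyl to tert-butyl (methyl in place of hydrogen on a saturated chain carbon bound to an aromatic nitrogen and two saturated chain carbons).

Among the compounds with values here, no measured step touches this place. All three change the group on a carbonyl carbon, and none has a readable size (a step that the two limits leave unreadable from compound 1 to compound 2) and (a step that the two limits leave unreadable from compound 1 to compound 3) and (a step that the two limits leave unreadable from compound 2 to compound 3). They therefore give no size to carry over, and in this assay no step beyond the scatter is expected in either direction. This is a weak expectation.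

The expected step is a step that the limit leaves unreadable from compound 2 to compound 4 and it rests on the small structural change alone. Compound 4 is estimated at 1.5 h with a range from 0.7 h to 4 h. Compound 4 may again give only a limit.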

Compound 4, half-life: 0.433 h
The estimate for compound 4 lay 3.5-fold (0.54 log units) above the measured number; the measured number lies below the stated range.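

In this assay, within the data shown here, isopropyl to tert-butyl, on a saturated chain carbon bound to an aromatic nitrogen, gives an at least 2.3-fold lower number from compound 2 to compound 4 (0.36 log units; beyond the scatter), the first readable step and the first at this place. Compound 2 gives > 1 h, which is a limit and not a number. The earlier steps, all on a carbonyl carbon, cannot be read, and this one has only a lower bound on its size because the compound it starts from sits at a limit: the limit of > 1 h in this assay, at which 3 of the 4 values shown sit.

On these data alone, whether tert-butyl lowers the number in the same way with isopropyl or tert-butoxy on the carbonyl carbon, in place of pentan-3-yl, remains open. Also open, as far as these compounds go, is where an ethyl or a cyclopropyl in place of isopropyl would fall in this assay.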